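A few compounds are considered here, and "the series" means these few. Any claim that something is new, unique, unknown or untested is made for them only; others in the source may bear on it.

Measured in a functional assay on MDA-MB-231 cells (Homo sapiens) for cytotoxicity, read by MTT assay, with a stated time of 38 h; a higher number here means a weaker inhibitor, a lower number a stronger inhibitor:
- compound 1 `CCN(CC)CCCCOc1c(-c2cc(OC)c(OC)c(OC)c2)oc2cc(OC)cc(OC)c2c1=O` gives 13000 nM
- compound 2 `COc1cc(OC)c2c(=O)c(OCCCN3CCN(C)CC3)c(-c3cc(OC)c(OC)c(OC)c3)oc2c1` gives 30100 nM

Compound 2 holds the higher of the two numbers. The next step leads to compound 3 `COc1cc(OC)c2c(=O)c(OCCCCN3CCN(C)CC3)c(-c3cc(OC)c(OC)c(OC)c3)oc2c1` and reads ((4-methylpiperazin-1-yl)methyl in place of 4-methylpiperazin-1-yl on a saturated chain carbon, three bonds along the chain from an oxygen on an aromatic ring). This places (4-methylpiperazin-1-yl)methyl in place of 4-methylpiperazin-1-yl, so 3-(4-methylpiperazin-1-yl)propyl becomes 4-(4-methylpiperazin-1-yl)butyl.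

Going by the values given here, the only measured step bearing on this is a 2.3-fold higher number from compound 1 to compound 2 (0.36 log units; beyond the scatter), which is modest. It puts 4-methylpiperazin-1-yl in place of (diethylamino)methyl at the same place, so the end group and the chain change together. Among the compounds with values here, no measured pair isolates the added chain carbon. With that one step as a guide, only a small move toward a lower number is expected in this assay, a 1.5-fold lower number from compound 2 to compound 3 (0.18 log units; within the scatter). For compound 3 the estimated value is 20000 nM, with an expected range of 8000 nM to 50000 nM.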

Compound 3, half-maximal inhibitory concentration: 3870 nM
The estimate for compound 3 lay 5.2-fold (0.71 log units) above the measured number; measured number outside the range, below it.
By their numbers in this assay, from the lowest: compound 3; then compound 1; then compound 2.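

In this assay, the change from 3-(4-methylpiperazin-1-yl)propyl to 4-(4-methylpiperazin-1-yl)butyl isolates chain length with the end group held constant, and the number falls (a 7.8-fold lower number from compound 2 to compound 3 (0.89 log units; beyond the scatter)). With the butyl chain held constant, 4-methylpiperazin-1-yl in place of diethylamino also gives a lower number (a 3.4-fold lower number from compound 1 to compound 3 (0.53 log units; beyond the scatter)), a direction that the earlier step could not show, since it changed the end group and the chain together. No measured evidence accounts for either step.

Going by these compounds, whether a longer chain such as 5-(4-methylpiperazin-1-yl)pentyl would lower the number further remains open. Also open, on these data alone, is how a morpholine or piperidine end group on the butyl chain would compare with 4-methylpiperazin-1-yl.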